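A few compounds are considered here, and "the series" means these few. Any claim that something is new, unique, unknown or untested is made for them only; others in the source may bear on it.

Compound 1, `COc1ccc(C2C(C(=O)Nc3ccc(Cl)cc3)=C(C)NC(C)=C2C(=O)Nc2ccc(Cl)cc2)cc1`, was examined in an ADME assay on Vero cells (Chlorocebus sabaeus) for cytotoxicity, read by sulforhodamine B assay, with a stated time of 3 days (on this read-out higher numbers stand for lower toxicity in this test and lower numbers for higher toxicity in this test), and gives 20 ug/mL. Compound 2, `CC1=C(C(=O)Nc2ccc(Cl)cc2)C(c2ccco2)C(C(=O)Nc2ccc(Cl)cc2)=C(C)N1`, carries furan-2-yl in place of 4-methoxyphenyl on a saturated ring carbon. In this assay compound 2 gives 24 ug/mL, and the step of a 1.2-fold higher number from compound 1 to compound 2 (0.08 log units; within the scatter) is small. Compound 3, `COc1ccc(NC(=O)C2=C(C)NC(=S)NC2c2ccc(OC)cc2)cc1`, is built on a different core from compound 1; the difference between the two cores is not broken down here. In this assay compound 3 gives 150 ug/mL, the highest of the three numbers, with steps to compound 2 and to compound 1 that both lie beyond the scatter.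

Compound 4, `COc1ccc(NC(=O)C2=C(C)NC(=S)NC2c2ccco2)cc1`, has not yet been measured. It differs from compound 3 by furan-2-yl in place of 4-methoxyphenyl on a saturated ring carbon. This is the same kind of change as that from compound 1 to compound 2, though the surroundings are not identical: in compound 3 the saturated ring carbon sits in a six-membered non-aromatic ring with 2 nitrogen, next to the ring nitrogen and next to the ring atom that bears a large group, two ring bonds from the ring atom that bears a methyl group, whereas in compound 1 it sits in a ring with 1 nitrogen, next to two ring atoms that each bear a (4-chlorophenyl)carbamoyl group and two ring bonds from two ring atoms that each bear a methyl group.

Because the step of a 1.2-fold higher number from compound 1 to compound 2 (0.08 log units; within the scatter) stayed within the scatter, a step of similar small size is expected for compound 4, a 1.1-fold higher number from compound 3 to compound 4 (0.03 log units; within the scatter). Compound 4 is therefore estimated at 160 ug/mL in this assay, with a likely range from 80 ug/mL to 320 ug/mL.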

Compound 4, half-maximal cytotoxic concentration: 230 ug/mL
The estimate for compound 4 lay 1.4-fold (0.16 log units) below the measured number, and the stated range covers the measured number.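

In this assay, furan-2-yl in place of 4-methoxyphenyl on the saturated ring carbon gave a 1.5-fold higher number from compound 3 to compound 4 (0.19 log units; within the scatter), so on this core too the change stayed within the usual scatter of repeated measurements. Set beside the earlier pair, the change reads alike on the two cores, with no difference that can be told from the scatter: the same change on two cores in this assay, a 1.2-fold higher number (0.08 log units; within the scatter) from compound 1 to compound 2 and a 1.5-fold higher number (0.19 log units; within the scatter) from compound 3 to compound 4, 1.3-fold (0.11 log units) apart, within the scatter of two such steps. This shows that, for these two pairs and in this one test, the exchange carried from one core to the other without a step that can be distinguished from zero, but it does not show that furan-2-yl and 4-methoxyphenyl truly give equal numbers, that the same would hold on a third core, or that it would hold in any other test.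

The compounds shown leave open whether a group of another kind on the saturated ring carbon, such as a simple alkyl chain, a carboxylic acid or an amine, would also leave the number in place. Among the compounds shown here, they also leave open whether either core would tolerate such a group equally, since only two aromatic rings have been compared at this position on each.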